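Swapping a small core substituent in a cytotoxicity screen

This account rests on a few compounds, and the source may have more. Where it says the series, first, only, none or still open, it means among the compounds named here.

Measured compounds:
- compound 1, `Cc1ccn2nc(C)c(C(=O)NCc3ccc(C(F)(F)F)cc3)c2c1`: > 100000 nM
- compound 2, `Cc1ccn2nc(C)c(C(=O)NCc3ccc(-c4ccc(OC(F)(F)F)cc4)cc3)c2c1`: 50700 nM
- compound 3, `Cc1ccc2c(C(=O)NCc3ccc(N4CCC(c5ccc(OC(F)(F)F)cc5)CC4)cc3)c(C)nn2c1`: > 100000 nM

All three compounds were tested in an ADME assay on Vero cells (Chlorocebus sabaeus) for cytotoxicity, read by CCK-8 assay, with a stated time of 72 h; on this read-out higher numbers stand for weaker inhibition and lower numbers for stronger inhibition. In this assay compound 2 gives 50700 nM, a number rather than a limit. Compound 1 reaches only a limit of the assay, > 100000 nM. Compound 3 likewise reaches only a limit of the assay, > 100000 nM, so no true number is known for it. Where compound 3 stands can therefore be said only loosely: it sits at the limit of > 100000 nM in this assay, at which 2 of the 3 values shown sit, together with compound 1, while compound 2 is the only one with a measured number.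

The next compound, compound 4, `COc1ccn2nc(C)c(C(=O)NCc3ccc(N4CCC(c5ccc(OC(F)(F)F)cc5)CC4)cc3)c2c1`, has not yet been tested. It differs from compound 3 in one place: a group of 12 heavy atoms (9 carbon, 2 nitrogen, 1 oxygen; one five-membered aromatic ring with 2 hetero atoms, one six-membered aromatic ring with 1 hetero atom) in place of a group of 11 heavy atoms (9 carbon, 2 nitrogen; one five-membered aromatic ring with 2 hetero atoms, one six-membered aromatic ring with 1 hetero atom), on a carbonyl carbon. No comparison between two measured compounds of this kind exists among the three shown, so the direction of the step has to be guessed. A change this small, in a compound that already sits at the limit, is expected to move the value by no more than the usual scatter, if at all, giving an estimated step of a number no higher from compound 3 to compound 4 (the limit leaves the size open). For compound 4 in this assay the expected value is 100000 nM, in a range from 50000 nM to 200000 nM, with a good chance that only a limit is reported again.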

Compound 4, half-maximal inhibitory concentration: > 100000 nM
Compound 4 gave a limit, no number; the forecaster's own chance of this, stated with the estimate: 70%; the middle value sits exactly at the limit.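

Compound 3 and compound 4 each reach only a limit in this assay, so no step between them can be read: the limit of > 100000 nM in this assay, at which 3 of the 4 values shown sit.

The compounds shown leave open where the true values of compound 3 and compound 4 lie, and so whether swapping the group on the carbonyl carbon changes the read-out at all.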